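Chloro on the core of compound 1: expected effect

A few compounds are considered here, and "the series" means these few. Any claim that something is new, unique, unknown or untested is made for them only; others in the source may bear on it.

Compound 1 `O=C(CCCc1ccccc1)Nc1nc2ccccc2c(=O)s1` gives 186 nM in an assay on mitochondria (strain Sprague-Dawley) for inhibition of Amine oxidase [flavin-containing] B (Rattus norvegicus), read by fluorescence and Amplex Red, with stated times of 30 min and 45 min; on this read-out lower numbers stand for stronger inhibition and higher numbers for weaker inhibition. Compound 2 `O=C(C/C=C/c1cccc(Cl)c1)Nc1nc2ccccc2c(=O)s1` gives 840 nM in this assay, and compound 3 `O=C(C/C=C/c1ccc(Cl)c(Cl)c1)Nc1nc2ccccc2c(=O)s1` gives 4640 nM. The difference between the cores of compound 1 and compound 2 is not broken down here. From compound 2 to compound 3 the change is chloro in place of hydrogen on an aromatic carbon, with a step of a 5.5-fold higher number from compound 2 to compound 3 (0.74 log units; beyond the scatter). Compound 4 `O=C(CCCc1ccccc1)Nc1nc2cc(Cl)ccc2c(=O)s1` carries the same kind of change, (chloro in place of hydrogen on an aromatic carbon), but at a different place: in compound 3 the chloro sits ortho to a chloro group and para to a large group, whereas in compound 4 it sits on a ring that is part of a fused or bridged system of two rings, meta to a fused ring and para to a fused ring. Because a 5.5-fold higher number from compound 2 to compound 3 (0.74 log units; beyond the scatter) weakened inhibition, a smaller weakening is expected here too, a 1.9-fold higher number from compound 1 to compound 4 (0.27 log units; within the scatter), though the different place leaves this uncertain. Compound 4 is therefore expected to give 350 nM, between 120 nM and 1100 nM.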

Compound 4, half-maximal inhibitory concentration: 1220 nM
Beside the measured number, compound 4's estimate is 3.5-fold (0.54 log units) below it; measured number outside the range, above it.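

In this assay the chloro change weakens inhibition on both cores, and the new step, a 6.6-fold higher number from compound 1 to compound 4 (0.82 log units; beyond the scatter), stands close to the earlier one: the same change on two cores in this assay, a 5.5-fold higher number (0.74 log units; beyond the scatter) from compound 2 to compound 3 and a 6.6-fold higher number (0.82 log units; beyond the scatter) from compound 1 to compound 4, 1.2-fold (0.07 log units) apart, within the scatter of two such steps. The change therefore carries over in direction and size between these two cores, although the chloro sits at a different place in each. Going by these compounds alone, this rests on only two steps, and compound 2 already carries a chloro before its step, so no general rule for the series follows, and the reason for the weakening remains unknown.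

Open, on these data alone, is whether a chloro at other places on the core of compound 1 gives a step of this size. Also open, as far as these compounds go, is whether fluoro, methoxy or an amine in the place of this chloro weakens inhibition as well.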